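This account rests on a few compounds, and the source may have more. Where it says the series, first, only, none or still open, it means among the compounds named here.

Measured compounds:
Compound 1 `CCC1(Cc2ccccc2)OS(=O)(=O)C=C1OCC#N` — in an ADME assay on HEL cells (Homo sapiens) for cytotoxicity, with a stated time of 3 days (on this read-out higher numbers stand for lower toxicity in this test and lower numbers for higher toxicity in this test), compound 1 gives > 200000 nM, which is a limit of the assay and not a number.
Compound 2 `CCC1(Cc2ccccc2)OS(=O)(=O)C=C1OCC1CCCCC1` — in this assay compound 2 gives > 200000 nM, again a limit of the assay.
Compound 3 `CC1(Cc2ccccc2)OS(=O)(=O)C=C1OCc1ccccc1` — in this assay compound 3 gives 68000 nM.

Compound 2 therefore stands at the top of what this assay can report: the limit of > 200000 nM in this assay, at which 2 of the 3 values shown sit. Where it would sit as a real number is not known.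

The step to compound 4 `CCC1(Cc2ccccc2)OS(=O)(=O)C=C1OCC=C(C)C` is this change: 2-methylprop-1-en-1-yl in place of cyclohexyl on a saturated chain carbon bound to an oxygen on an unsaturated carbon. Going by the values given here, only one measured step touches the same place on the molecule, the step that the two limits leave unreadable from compound 1 to compound 2. Both of its ends are limits, so its size cannot be read. So no measured step gives a direction or a size for the change to compound 4; the shown values only say that compound 2 and compound 1 sit at the limit while compound 3, which differs elsewhere, is below it.

The step from compound 2 to compound 4 is therefore expected to be small or unreadable, a number no higher from compound 2 to compound 4 (the limit leaves the size open). In this assay compound 4 is estimated at 200000 nM, with a range from 60000 nM to 500000 nM, and most likely the assay will again report only its limit.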

Compound 4, half-maximal cytotoxic concentration: 112000 nM
Compound 4: the middle estimate sits 1.8-fold (0.25 log units) above what was measured; measured number inside the range.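

This position is not silent in this assay: with the shared core held constant, the group on the saturated chain carbon bound to an oxygen on an unsaturated carbon can bring the read-out down to a real number. The change to 2-methylprop-1-en-1-yl gives an at least 1.7-fold lower number from compound 2 to compound 4 (0.25 log units; that floor lies within the scatter), and measured against the nitrile-bearing compound it gives an at least 1.7-fold lower number from compound 1 to compound 4 (0.25 log units; that floor lies within the scatter). Going by these compounds, each of these steps starts from a limit, so its true size is unknown and even its smallest possible size does not clear the usual scatter, which makes this a first hint of higher toxicity in this test and not an established change; compound 1 and compound 2 remain at the top of what can be reported: the limit of > 200000 nM in this assay, at which 2 of the 4 values shown sit.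

The compounds shown leave open whether the double bond or the loss of the cyclohexyl ring goes with the lower number, and a 3-methylbutyl group, which keeps the open chain without the double bond, would separate the two. They also leave open how an amine or a carboxylic acid at this place, or a longer chain, would read in this assay.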